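Swapping phenyl for cyclohexyl at the far end of the chain

The compounds below may be only part of what the source reports. "The series", "measured", "known", "first", "only" and "open" are said of these compounds alone.

Compound 1 `CC(C)c1ccc(OCC(=O)Nc2cccc(-c3nc4ncccc4o3)c2)cc1`: 2100 nM
Compound 2 `O=C(COc1ccc(-c2ccccc2)cc1)Nc1ccccc1-c1nc2ncccc2[nH]1`: 1100 nM

Both were tested in an assay on brain for inhibition of Fatty-acid amide hydrolase 1 (Rattus norvegicus); on this read-out lower numbers stand for stronger inhibition and higher numbers for weaker inhibition. Compound 2 gives 1100 nM and compound 1 gives 2100 nM; these two numbers lie within the usual scatter of each other, so neither compound can be called stronger. Compound 3 `O=C(COc1ccc(C2CCCCC2)cc1)Nc1ccccc1-c1nc2ncccc2[nH]1` differs from compound 2 by a single change: cyclohexyl in place of phenyl on an aromatic carbon. Among the measured compounds shown here, no measured pair here shows what such a change does, so in this assay only a small step is expected, possibly none beyond the scatter. The step expected for compound 3 is a 1.4-fold lower number from compound 2 to compound 3 (0.14 log units; within the scatter). Compound 3 is estimated at 800 nM, with a range from 250 nM to 2500 nM.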

Compound 3, half-maximal inhibitory concentration: 650 nM
Estimate against measurement, compound 3: 1.2-fold (0.09 log units) above; the range from low to high includes it.
By their numbers in this assay, from the lowest: compounds 3, 2 and 1 (each within the scatter of the next, the first and the last beyond it).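

In this assay, cyclohexyl in place of phenyl on this aromatic carbon, para to a large group, gives a 1.7-fold lower number from compound 2 to compound 3 (0.23 log units; within the scatter) and so leaves the two compounds indistinguishable. Among the compounds shown here, this is the first pair here that differs in one place, and it shows that an aromatic ring at this position is not needed to keep inhibition at this level. No other data here bear on this result. On these data alone, whether a ring holding an amine, such as piperidinyl, would read the same here remains open. So does whether a much smaller group, such as methyl, would.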